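From 4-aminophenyl to 4-fluorobenzyl on the shared core

The source may hold more compounds than are shown below. What is called first, only, known or untested is meant among the compounds shown, and "the series" means these compounds.

Within the data shown here, in a functional assay on HCT-116 cells (Homo sapiens) for cytotoxicity, read by MTT assay, with a stated time of 72 h (on this read-out higher numbers stand for weaker inhibition and lower numbers for stronger inhibition), compound 3 `Nc1ccc(Nc2c(C(=O)NCc3ccc(F)cc3)nc(Br)c3cccnc23)cc1` gives 7000 nM, the lowest number so far. Its nearest neighbour, compound 2 `NCCCNc1c(C(=O)NCc2ccc(F)cc2)nc(Br)c2cccnc12`, gives 18000 nM, and the measured gap is a 2.6-fold lower number from compound 2 to compound 3 (0.41 log units; beyond the scatter). Compound 1 `C[C@@H](Nc1c(C(=O)NCc2ccc(F)cc2)nc(Br)c2cccnc12)c1ccccc1` reads > 20000 nM, which is a limit of the assay and not a number. The step into the 4-aminophenyl group from that limit is an at least 2.8-fold lower number from compound 1 to compound 3 (0.45 log units; beyond the scatter). The remaining step is an at least 1.1-fold lower number from compound 1 to compound 2 (0.04 log units; that floor lies within the scatter).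

Compound 4 `O=C(NCc1ccc(F)cc1)c1nc(Br)c2cccnc2c1NCc1ccc(F)cc1` differs from compound 3 by 4-fluorobenzyl in place of 4-aminophenyl on a nitrogen on an aromatic ring. Among the measured compounds shown here, no measured step covers this exact change. The closest guides are the two steps into the 4-aminophenyl group, which were modest, so removing that group is expected to run the other way. The expected change in this assay is a 2.4-fold higher number from compound 3 to compound 4 (0.39 log units; beyond the scatter), modest in size and towards weaker inhibition. For compound 4 the estimate is 17000 nM, with an expected range of 8000 nM to 40000 nM.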

Compound 4, half-maximal inhibitory concentration: > 20000 nM
Compound 4: no number, only a limit (the forecaster's own chance of this, stated with the estimate: 40%); middle value at least 1.1-fold (0.07 log units) from the limit.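

In this assay compound 4 gives > 20000 nM, which is a limit of the assay and not a number. The 4-fluorobenzyl group also carries a six-membered aromatic ring of carbon only, yet the change gives an at least 2.8-fold higher number from compound 3 to compound 4 (0.45 log units; beyond the scatter), so that ring alone does not account for the lower number of compound 3, while an at least 1.1-fold higher number from compound 2 to compound 4 (0.04 log units; that floor lies within the scatter) leaves compound 2 and compound 4 unseparated. The step between compound 1 and compound 4 cannot be read, and the comparisons at this position are bounded by a shared limit: the limit of > 20000 nM in this assay, at which 2 of the 4 values shown sit.

The compounds shown leave open whether the lower number of compound 3 follows the amine or the ring bound directly to the nitrogen on the aromatic ring. A 4-aminobenzyl or an unsubstituted phenyl group at this position would separate the two.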